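The source may report more compounds than this note shows. Statements on the series, on what has been measured and on what is new or still open speak of the compounds shown alone.

Compound 1 `CC(=O)N1N=C(c2ccc(-n3nc(C)n(N)c3=O)cc2)CC1c1cccc(Cl)c1`: 96.5%
Compound 2 `CC(=O)N1N=C(c2ccc(-n3nc(C)n(N)c3=O)cc2)CC1c1ccc(Cl)cc1`: 126%

Within the data shown here, in an assay on isolated protein for inhibition of pancreatic alpha-amylase (Homo sapiens), with a stated time of 10 min, tested at 1 mg/mL (on this read-out lower numbers stand for less inhibition and higher numbers for more inhibition at the one concentration tested (going by the name of the read-out)), compound 2 gives 126%, the higher of the two numbers measured; compound 1 gives 96.5%, and the one measured step, a number 29.5 percentage points higher from compound 1 to compound 2 (beyond the scatter), moves the chloro rather than exchanging it. Compound 3 `CC(=O)N1N=C(c2ccc(-n3nc(C)n(N)c3=O)cc2)CC1c1ccc(O)cc1` differs from compound 2 by hydroxy in place of chloro on an aromatic carbon. Among the measured compounds shown here, no measured step covers a hydroxy entering for a chloro, so the known step bears on it only indirectly. With that gap, compound 3 is expected to stay near compound 2, with a step of a number 26 percentage points lower from compound 2 to compound 3 (beyond the scatter) in this assay, estimated at 100%, between 60% and 135%.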

Compound 3, a percentage reported as inhibition, at one concentration (the size of the read-out at that concentration, not a potency): 76.7%
Beside the measured number, compound 3's estimate is 23.3 percentage points above it; the range from low to high includes it.
By their numbers in this assay, from the lowest: compound 3; then compound 1; then compound 2.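

In this assay, the earlier pair only moved the chloro around the ring, whereas here the chloro itself is exchanged on the same aromatic carbon: a number 49.3 percentage points lower from compound 2 to compound 3 (beyond the scatter), a large step, so the group at this carbon matters as well as its place. Set against the other chloro compound, a number 19.8 percentage points lower from compound 1 to compound 3 (beyond the scatter), which leaves compound 3 lowest of the three. No available evidence accounts for this drop. On these data alone, whether methoxy, an amine or a carboxylic acid on this carbon would give a number nearer compound 2 or compound 3 remains open.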